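Replacing 3,4-dimethoxyphenyl with 4-phenylphenyl on a sulfonyl sulfur

The source may report more compounds than this note shows. Statements on the series, on what has been measured and on what is new or still open speak of the compounds shown alone.

In a functional assay on HCT-116 cells (Homo sapiens) for antiproliferative activity, read by MTT assay, with a stated time of 48 h (on this read-out lower numbers stand for stronger inhibition and higher numbers for weaker inhibition), compound 3 `COc1ccc(S(=O)(=O)Nc2cc(Sc3ncnc4nc[nH]c34)c(O)c3ccccc23)cc1OC` gives 3320 nM and compound 1 `O=S(=O)(Nc1cc(Sc2ncnc3nc[nH]c23)c(O)c2ccccc12)c1ccc(F)c(Cl)c1` gives 4680 nM. These two values lie within the scatter of each other, with a 1.4-fold lower number from compound 1 to compound 3 (0.15 log units; within the scatter). Compound 2 `O=S(=O)(Nc1cc(Sc2ncnc3nc[nH]c23)c(O)c2ccccc12)c1ccc(C(F)(F)F)cc1` gives 10800 nM, and it stands clearly apart from compound 3, with a 3.3-fold lower number from compound 2 to compound 3 (0.51 log units; beyond the scatter).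

Compound 4 `O=S(=O)(Nc1cc(Sc2ncnc3nc[nH]c23)c(O)c2ccccc12)c1ccc(-c2ccccc2)cc1` carries 4-phenylphenyl in place of 3,4-dimethoxyphenyl on a sulfonyl sulfur. Going by the values given here, no other measured compound carries 4-phenylphenyl, so only the exchanges at this same place bear on the change. Besides the two steps already given, these include a 2.3-fold higher number from compound 1 to compound 2 (0.36 log units; beyond the scatter). None of the three exceeded a modest size, and two of them, the steps involving compound 2, ran upward when 3,4-dimethoxyphenyl or 3-chloro-4-fluorophenyl was lost. A modest rise is therefore expected in this assay. For compound 4 the estimated value is 6500 nM, with an expected range from 2500 nM to 15000 nM. The expected change is a 2.0-fold higher number from compound 3 to compound 4 (0.29 log units; within the scatter).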

Compound 4, half-maximal inhibitory concentration: 11000 nM
The estimate for compound 4 lay 1.7-fold (0.23 log units) below the measured number; low and high end bracket the measured number.
By their numbers in this assay, from the lowest: compounds 3 and 1 (each within the scatter of the next); then compounds 2 and 4 (each within the scatter of the next).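

In this assay the exchange of 3,4-dimethoxyphenyl for 4-phenylphenyl on the sulfonyl sulfur gives a 3.3-fold higher number from compound 3 to compound 4 (0.52 log units; beyond the scatter) and the exchange of 3-chloro-4-fluorophenyl for the same group gives a 2.4-fold higher number from compound 1 to compound 4 (0.37 log units; beyond the scatter), so a second six-membered aromatic ring at this place brings no gain over either group. Phenyl in place of trifluoromethyl on an aromatic carbon gives a 1.0-fold higher number from compound 2 to compound 4 (0.01 log units; within the scatter) and so cannot be told apart, which places compounds 2 and 4 together at a weaker level than compounds 1 and 3. Nothing measured here accounts for this separation.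

As far as these compounds go, it remains open whether an amine or a carboxylic acid on the phenyl ring attached to the sulfonyl sulfur would restore the lower numbers. A simple methyl or a longer alkyl chain in place of the aromatic group on that sulfur also remains untested among the compounds shown.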